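Swapping a Furan for a Methylisoxazole on a Fused Core

The source may hold more compounds than are shown below. What is called first, only, known or untested is meant among the compounds shown, and "the series" means these compounds.

Measured so far:
compound 1 `Cc1cc(CN2CCN(c3c(Cl)cnc4[nH]c(-c5ccoc5)nc34)CC2)no1`: 6500 nM
compound 2 `Cc1cc(CN2CCN(c3c(Br)cnc4[nH]c(-c5nc(C)oc5C)nc34)CC2)no1`: 4570 nM
compound 3 `Cc1cc(CN2CCN(c3c(Br)cnc4[nH]c(-c5csnn5)nc34)CC2)no1`: 20000 nM

In a functional assay on SW-620 cells (Homo sapiens) for inhibition, read by MTT assay, with a stated time of 72 h (a higher number here means a weaker inhibitor of growth, a lower number a stronger inhibitor of growth), compound 1 gives 6500 nM, the second highest number of the three; compound 2 lies within the scatter of it, while compound 3 gives a number beyond the scatter above it. Compound 4 `Cc1cc(CN2CCN(c3c(Cl)cnc4[nH]c(-c5cc(C)on5)nc34)CC2)no1` differs from compound 1 by one change: 5-methyl-1,2-oxazol-3-yl in place of furan-3-yl on an aromatic carbon. Among the compounds with values here, the only measured step at the same place is a 4.4-fold higher number from compound 2 to compound 3 (0.64 log units; beyond the scatter), where a ring with more hetero atoms replaced another and the number rose. Both moves put a ring with two hetero atoms onto the same aromatic carbon, so a modest rise, or none beyond the scatter, is expected here, as a 1.4-fold higher number from compound 1 to compound 4 (0.14 log units; within the scatter). Compound 4 is therefore estimated at 9000 nM, between 3500 nM and 25000 nM.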

Compound 4, concentration for 50% growth inhibition: 1150 nM
For compound 4 the middle estimate is 7.8-fold (0.89 log units) above the measured one; measured number outside the range, below it.
By their numbers in this assay, from the lowest: compound 4; then compounds 2 and 1 (each within the scatter of the next); then compound 3.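

In this assay, the step at this aromatic carbon is a drop in the number: a 5.7-fold lower number from compound 1 to compound 4 (0.75 log units; beyond the scatter). A ring with more hetero atoms therefore lowers the number here, whereas a 4.4-fold higher number from compound 2 to compound 3 (0.64 log units; beyond the scatter) goes the other way, so the count of hetero atoms alone does not set the direction at this place. No measurement available here explains the drop.

The change adds a ring nitrogen and a methyl together, and the compounds shown cannot separate the two. From the compounds shown here alone, it also remains open how an ethyl group or an aminomethyl group in place of that methyl would read.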